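The source may report more compounds than this note shows. Statements on the series, on what has been measured and on what is new or still open speak of the compounds shown alone.

In a functional assay on MCF7 cells (Homo sapiens) for antiproliferative activity, read by sulforhodamine B assay, with a stated time of 48 h (on this read-out higher numbers stand for weaker inhibition and lower numbers for stronger inhibition), compound 1 `CCc1ccc(NS(=O)(=O)c2ccc(N3CCNC3=O)cc2)cc1` gives 810 nM, while compound 2 `O=C1NCCN1c1ccc(S(=O)(=O)Nc2cccc(Cl)c2)cc1` gives 79 nM, the lower of the two numbers. Compound 3 `Cc1ccc(NS(=O)(=O)c2ccc(N3CCNC3=O)cc2)c(C)c1` carries 2,4-dimethylphenyl in place of 3-chlorophenyl on a sulfonamide nitrogen of compound 2: 2,4-dimethylphenyl in place of 3-chlorophenyl on a sulfonamide nitrogen. Within the data shown here, one measured step bears on this change: a 10-fold lower number from compound 1 to compound 2 (1.01 log units; beyond the scatter), which is large and beyond the scatter and put 3-chlorophenyl in place of 4-ethylphenyl at that nitrogen. Compound 3 again has a carbon-only substituent set, so a higher number is expected in this assay. The expected step is a 3.8-fold higher number from compound 2 to compound 3 (0.58 log units; beyond the scatter). For compound 3 the estimate is 300 nM, with an expected range of 90 nM to 1000 nM.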

Compound 3, half-maximal inhibitory concentration: 230 nM
Estimate against measurement, compound 3: 1.3-fold (0.12 log units) above, and the stated range covers the measured number.
By their numbers in this assay, from the lowest: compound 2; then compound 3; then compound 1.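

In this assay the change to 2,4-dimethylphenyl on a sulfonamide nitrogen gives a 2.9-fold higher number from compound 2 to compound 3 (0.46 log units; beyond the scatter), so 3-chlorophenyl keeps the lowest number of the three compounds. Losing chlorine does not alone set the number, since the two groups of carbon only also differ: the change from 4-ethylphenyl to 2,4-dimethylphenyl gives a 3.5-fold lower number from compound 1 to compound 3 (0.55 log units; beyond the scatter). No measurement here explains either step.

The compounds shown leave open whether 3-methylphenyl would match 3-chlorophenyl at this nitrogen, and how a phenyl ring carrying a methoxy group or an amine would read.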